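The source may report more compounds than this note shows. Statements on the series, on what has been measured and on what is new or still open speak of the compounds shown alone.

Among the measured compounds shown here, compound 2, `Cc1ccccc1Cc1ccc(N2C[C@@H](C)C[C@H]2CC(=O)O)cc1`, is the only compound with a definite number in a functional assay on cells for agonist activity at Free fatty acid receptor 1 (Mus musculus), read by FLIPR and calcium flux, with a stated time of 100 s (a higher number here means that more compound is needed for the effect, a lower number that less compound is needed), where compound 2 gives 1100 nM. Compound 1, `Cc1ccccc1Cc1ccc(N2CCC[C@H]2CC(=O)O)cc1`, sits at the limit of > 33000 nM in this assay, at which 1 of the 2 values shown sits; compound 1 gives > 33000 nM, a limit and not a number. For the measured compounds named here, the one measured step, an at least 30-fold lower number from compound 1 to compound 2 (1.47 log units; beyond the scatter), shows how much a group on this saturated ring carbon can matter. Compound 3, `Cc1ccccc1Cc1ccc(N2C[C@@H](C(F)(F)F)C[C@H]2CC(=O)O)cc1`, carries trifluoromethyl in place of methyl on a saturated ring carbon. Going by the values given here, no measured step exchanges methyl for trifluoromethyl, so a change within the scatter is expected. Compound 3 is estimated at 900 nM, between 300 nM and 3000 nM, an expected step of a 1.2-fold lower number from compound 2 to compound 3 (0.09 log units; within the scatter).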

Compound 3, half-maximal effective concentration: 710 nM
The estimate for compound 3 lay 1.3-fold (0.10 log units) above the measured number, and the stated range covers the measured number.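

Trifluoromethyl on this saturated ring carbon serves as well as methyl: the exchange gives a 1.5-fold lower number from compound 2 to compound 3 (0.19 log units; within the scatter), so the two groups cannot be told apart in this assay. Set against hydrogen, trifluoromethyl gives an at least 46-fold lower number from compound 1 to compound 3 (1.66 log units; beyond the scatter), so the large step seen earlier is not unique to methyl. That step rests on a limit, which belongs to compound 1: the limit of > 33000 nM in this assay, at which 1 of the 3 values shown sits. Still open, from the compounds shown here alone, is what an ethyl group, a hydroxyl group or an amine would give on this carbon, and whether the mirror-image arrangement of the group at this carbon would give the same number.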